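Tetrabromobenzotriazole alcohols: dropping the aryl halide

The source may report more compounds than this note shows. Statements on the series, on what has been measured and on what is new or still open speak of the compounds shown alone.

Measured compounds:
compound 1, `OC(CCn1nc2c(Br)c(Br)c(Br)c(Br)c2n1)c1cccc(Br)c1`: 0%
compound 2, `OC(CCn1nc2c(Br)c(Br)c(Br)c(Br)c2n1)c1ccc(F)cc1`: 0%
compound 3, `OC(CCn1nc2c(Br)c(Br)c(Br)c(Br)c2n1)c1cccc(Cl)c1`: 0%

Three analogues built on a shared core have been tested in a functional assay on CCRF-CEM cells (Homo sapiens) for antiproliferative activity, read by MTT assay, with a stated time of 24 h, tested at 100 uM; on this read-out higher numbers stand for a weaker effect at the one concentration tested and lower numbers for a stronger effect. Compound 1 gives 0%, compound 2 gives 0%, and compound 3 gives 0%. Compound 3 therefore stands level with compounds 1 and 2 at the digits shown; neither its nearest neighbour, compound 1, nor compound 2 is separated from it by more than the scatter.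

The next compound, compound 4, `OC(CCn1nc2c(Br)c(Br)c(Br)c(Br)c2n1)c1ccccc1`, differs from compound 3 by hydrogen in place of chloro on an aromatic carbon, on an aromatic carbon of a six-membered aromatic ring of carbon only.

Among the measured compounds shown here, three measured steps bear on this change. The exchange of one ring halogen for another, no change at the digits printed from compound 1 to compound 3 (within the scatter), moved nothing. The larger swaps of the whole aryl group, no change at the digits printed from compound 1 to compound 2 (within the scatter) and no change at the digits printed from compound 2 to compound 3 (within the scatter), likewise moved nothing. Removing the chloro entirely is expected to behave the same way, with no change at the digits printed from compound 3 to compound 4 (within the scatter), no change beyond the scatter. Compound 4 is therefore estimated at 0%, with a range from 0% to 10%.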

Compound 4, a percentage reported as activity, at one concentration (the size of the read-out at that concentration, not a potency): 21%
Compound 4: the middle estimate sits 21 percentage points below what was measured, and the stated range ends below it.
By their numbers in this assay, from the lowest: compounds 1, 2 and 3 (each within the scatter of the next); then compound 4.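

In this assay, taking the halogen off the aryl ring altogether does what swapping it never did: loss of chloro gives a number 21 percentage points higher from compound 3 to compound 4 (beyond the scatter), loss of fluoro gives a number 21 percentage points higher from compound 2 to compound 4 (beyond the scatter), and loss of bromo gives a number 21 percentage points higher from compound 1 to compound 4 (beyond the scatter). The aryl ring is therefore not a silent position in this series: the halogen's identity made no difference across compound 1, compound 2 and compound 3, yet the bare phenyl of compound 4 has the weaker effect at the one concentration tested. Nothing available explains this step.

From the compounds shown here alone, whether the effect needs a halogen as such or any group on this ring remains open, and a methyl, a methoxy or an amine there would test it. Going by these compounds, it is also open whether a ketone in place of the alcohol would change the read-out.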